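The compounds below may be only part of what the source reports. "The series", "measured", "known", "first", "only" and "open" are said of these compounds alone.

Working notes on the series. Compound 1 `COc1ccccc1N1CCN(C(=O)CCc2c(-c3ccc(Cl)cc3)[nH]c3cc(Cl)ccc23)CC1` gives 4.9 nM in an assay on CHO cells for displacement of a labelled ligand from Substance-P receptor (Homo sapiens) (on this read-out higher numbers stand for weaker inhibition and lower numbers for stronger inhibition), and compound 2 `COc1ccccc1N1CCN(C(=O)CCc2c(-c3ccc(Cl)cc3)[nH]c3c(Cl)cc(Cl)cc23)CC1` gives 14 nM. Within the data shown here, compound 3 `CC(=O)c1ccc2c(c1)c(CCC(=O)N1CCC(O)(Cc3ccccc3)CC1)c(-c1ccc(Cl)cc1)n2C` gives 0.19 nM, the lowest of the three numbers; its gap to compound 1 and its gap to compound 2 both lie beyond the scatter, so compound 3 is the most potent compound measured so far.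

The next step leads to compound 4 `Cn1c(-c2ccc(Cl)cc2)c(CCC(=O)N2CCC(O)(Cc3ccccc3)CC2)c2cc(-n3cccc3)ccc21`. The change is 1H-pyrrol-1-yl in place of acetyl on an aromatic carbon, in words 1H-pyrrol-1-yl in place of acetyl on an aromatic carbon. No comparable change has been measured, so the expected step is set small: a modest weakening or none beyond the scatter, with a 2.6-fold higher number from compound 3 to compound 4 (0.42 log units; beyond the scatter) as the expected step. Compound 4 is estimated at 0.5 nM, within a range of 0.1 nM to 3 nM.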

Compound 4, half-maximal inhibitory concentration: 2.3 nM
Compound 4: middle estimate off by 4.6-fold (0.66 log units), on the low side; the range from low to high includes it.
By their numbers in this assay, from the lowest: compound 3; then compound 4; then compound 1; then compound 2.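

Among these compounds, exchanging acetyl for 1H-pyrrol-1-yl on this aromatic carbon gives a 12-fold higher number from compound 3 to compound 4 (1.08 log units; beyond the scatter) and shows that the number depends strongly on the group at this position, which the earlier compounds could not show. Both groups count no hydrogen-bond donors and one acceptor, so that count does not separate them. Nothing available accounts for the size of this step.

Going by these compounds, it remains open whether a carboxylic acid, an amine or a methoxy group here would sit nearer compound 3 or compound 4. On these data alone, whether the step would keep its size with a different amide part is also open.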